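Replacing bromo with a dimethylcarbamoyl ethenyl group

The compounds below may be only part of what the source reports. "The series", "measured", "known", "first", "only" and "open" are said of these compounds alone.

In an assay on isolated protein with Bile acid receptor (Homo sapiens) as the target (a higher number here means that more compound is needed for the effect, a lower number that less compound is needed), compound 2 `COC(=O)/C=C/c1cccc(N(Cc2ccc(Br)cc2)C(=O)C2CCCCC2)c1` reports only the limit > 1000 nM, so only a bound is known for it. Compound 1 `COC(=O)/C=C/c1cccc(N(Cc2ccc(/C=C/c3cccc(F)c3)cc2)C(=O)C2CCCCC2)c1` gives 86 nM in this assay. The step of an at least 11-fold higher number from compound 1 to compound 2 (1.06 log units; beyond the scatter) is itself a lower bound because compound 2 sits at the limit of > 1000 nM in this assay, at which 1 of the 2 values shown sits. Compound 3 `COC(=O)/C=C/c1cccc(N(Cc2ccc(/C=C/C(=O)N(C)C)cc2)C(=O)C2CCCCC2)c1` reintroduces a large group on an aromatic carbon, para to a large group: 2-(dimethylcarbamoyl)ethenyl in place of bromo on an aromatic carbon. Among the measured compounds shown here, the one measured step bears directly on this change and was large, so a drop in the number beyond the scatter is expected, though full recovery to compound 1 is uncertain. Compound 3 is expected near 400 nM, between 100 nM and 2000 nM. The implied expected step is an at least 2.5-fold lower number from compound 2 to compound 3 (0.39 log units; beyond the scatter).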

Compound 3, half-maximal effective concentration: > 1000 nM
Compound 3: a limit, no number (the forecaster's own chance of this, stated with the estimate: 35%); middle value at least 2.5-fold (0.39 log units) from the limit.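

In this assay compound 3 gives > 1000 nM, a limit and not a number. With the ethenyl link kept, dimethylcarbamoyl in place of 3-fluorophenyl gives an at least 11-fold higher number from compound 1 to compound 3 (1.06 log units; beyond the scatter), so at this position the ethenyl link alone does not carry the value of compound 1, and what sits at the chain end counts. The step between compound 2 and compound 3 cannot be read, as both stand at the same limit: the limit of > 1000 nM in this assay, at which 2 of the 3 values shown sit.

Going by these compounds, whether the chain end needs the fluorine or only a ring stays open. A plain phenyl or a pyridine ring on the ethenyl link would separate the two.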